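Acetylsulfamoyl Substitution on the Shared Core of Compound 1

The source may hold more compounds than are shown below. What is called first, only, known or untested is meant among the compounds shown, and "the series" means these compounds.

Compound 1 `Oc1ccc(O)c(-c2cc(-c3ccccc3)nn2-c2ccccc2)c1` is the weaker of the two measured compounds: in a functional assay on cells (Leukemia cell, Homo sapiens) for cytotoxicity, read by sulforhodamine B assay, with a stated time of 48 h (a higher number here means a weaker inhibitor of growth, a lower number a stronger inhibitor of growth), compound 1 gives 35700 nM, the highest of the two numbers. Its nearest neighbour is compound 2 `Oc1ccc(O)c(-c2cc(-c3ccc(Cl)cc3)nn2-c2ccccc2)c1`, which in this assay gives 3430 nM; the step of a 10-fold lower number from compound 1 to compound 2 (1.02 log units; beyond the scatter) is large and beyond the scatter. Compound 3 `CC(=O)NS(=O)(=O)c1ccc(-n2nc(-c3ccccc3)cc2-c2cc(O)ccc2O)cc1` differs from compound 1 by acetylsulfamoyl in place of hydrogen on an aromatic carbon. Going by the values given here, no measured step covers this change: the only step available, from compound 1 to compound 2, concerns a different ring and a different group, so it bears on the expectation only as a sign that substitution on a phenyl ring of this core can shift this assay substantially. For compound 3 a modest change toward a lower number is expected, at the edge of the scatter, as a 1.8-fold lower number from compound 1 to compound 3 (0.25 log units; within the scatter). Compound 3 is therefore estimated at 20000 nM, within 5000 nM to 60000 nM.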

Compound 3, concentration for 50% growth inhibition: 93600 nM
The estimate for compound 3 lay 4.7-fold (0.67 log units) below the measured number, outside the stated range (above it).
By their numbers in this assay, from the lowest: compound 2; then compound 1; then compound 3.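

In this assay, acetylsulfamoyl on this aromatic carbon, para to a large group, gives a 2.6-fold higher number from compound 1 to compound 3 (0.42 log units; beyond the scatter), a modest move toward weaker inhibition of growth. The earlier step, a 10-fold lower number from compound 1 to compound 2 (1.02 log units; beyond the scatter), ran the other way with chloro on a different ring, so a substituent on the shared core does not lower the number in every case. Nothing at hand accounts for the direction or size of this shift.

From the compounds shown here alone, it remains open whether the rise belongs to the whole acetylsulfamoyl group or to one part of it, a question that a plain sulfamoyl group or a carboxylic acid at this position would help to answer. Going by these compounds, it is also open how a small group such as chloro or an amine would behave at this same place.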